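This account rests on a few compounds, and the source may have more. Where it says the series, first, only, none or still open, it means among the compounds named here.

Compound 1, `Fc1ccc2nc(-c3cncs3)n(C3CC3)c2c1`: in an assay on cells for inhibition of cytochrome P450 11B2, mitochondrial (Homo sapiens), read by HPLC, with a stated time of 90 min (a lower number here means a stronger inhibitor, a higher number a weaker inhibitor), compound 1 gives 62 nM.
Compound 2, `Fc1ccc2nc(-c3cncnc3)n(C3CC3)c2c1`: in this assay compound 2 gives 40 nM.
Compound 3, `Fc1ccc2nc(-c3ccnnc3)n(C3CC3)c2c1`: in this assay compound 3 gives 330 nM.

Compound 2 carries the lowest of the three numbers, though its gap to compound 1, a 1.6-fold lower number from compound 1 to compound 2 (0.19 log units; within the scatter), lies within the scatter, so these two cannot be told apart. Compound 3 sits further off, with an 8.3-fold higher number from compound 2 to compound 3 (0.92 log units; beyond the scatter) and a 5.3-fold higher number from compound 1 to compound 3 (0.73 log units; beyond the scatter) both beyond the scatter. Compound 4, `Fc1cc2nc(-c3cncnc3)n(C3CC3)c2cc1F`, has not yet been measured; it differs from compound 2 by fluoro in place of hydrogen on an aromatic carbon. Among the compounds with values here, all three measured steps exchange the group attached to the shared core, and none of them touches the part of the core where the new fluoro enters, so no measured step bears directly on this change. With nothing pointing either way, no step beyond the scatter is expected; the expected step is no change at the digits printed from compound 2 to compound 4 (within the scatter). Compound 4 is therefore estimated at 40 nM, with a range from 15 nM to 110 nM.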

Compound 4, half-maximal inhibitory concentration: 22 nM
Beside the measured number, compound 4's estimate is 1.8-fold (0.26 log units) above it; the range from low to high includes it.
By their numbers in this assay, from the lowest: compounds 4, 2 and 1 (each within the scatter of the next, the first and the last beyond it); then compound 3.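

Placing fluoro in place of hydrogen on the aromatic carbon ortho to the existing fluoro group gives a 1.8-fold lower number from compound 2 to compound 4 (0.26 log units; within the scatter) in this assay, so compound 2 and compound 4 cannot be told apart. Within the data shown here, the earlier compounds differed only in the group attached to the shared core, so this is the first measured step at this position of the core. It shows that this position can carry a fluoro with no change beyond the scatter, and nothing available explains the result.

Going by these compounds, whether a larger group at this position, such as chloro, methoxy or an amine, would give a similar number remains open. So does whether the same fluoro would give a similar step with the 1,3-thiazol-5-yl group of compound 1 or the pyridazin-4-yl group of compound 3.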